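The source may hold more compounds than are shown below. What is called first, only, known or untested is meant among the compounds shown, and "the series" means these compounds.

Measured compounds:
- compound 1, `CCOC(=O)COc1ccc2c(=O)c(-c3ccc(O)cc3)coc2c1`: 130 nM
- compound 2, `O=c1c(-c2ccc(O)cc2)coc2cc(OCCCCCCCCCCCCO)ccc12`: 1700 nM
- compound 3, `CCCCCCC(Oc1ccc2c(=O)c(-c3ccc(O)cc3)coc2c1)C(=O)O`: 2000 nM

In an assay (Cricetulus griseus) for inhibition of aldehyde dehydrogenase, mitochondrial (Homo sapiens) (a higher number here means a weaker inhibitor, a lower number a stronger inhibitor), compound 2 stands second highest of the three numbers. Its value sits within the scatter of compound 3, while compound 1 lies well beyond the scatter, at a far lower number. Compound 4, `O=C(O)CCCCCCCCCOc1ccc2c(=O)c(-c3ccc(O)cc3)coc2c1`, has not been measured in this assay. It differs from compound 2 in one place: carboxy in place of 3-hydroxypropyl on a saturated chain carbon, nine bonds along the chain from an oxygen on an aromatic ring. Among the measured compounds shown here, no step between measured compounds isolates this change, but compound 3, which also carries a carboxylic acid on the chain, gives 2000 nM, close to compound 2. The writer therefore expects no step beyond the scatter from compound 2 to compound 4, estimated as a 1.1-fold lower number from compound 2 to compound 4 (0.05 log units; within the scatter). Compound 4 is expected to give 1500 nM, within the range 500 nM to 5000 nM.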

Compound 4, half-maximal inhibitory concentration: 50 nM
The estimate for compound 4 lay 30-fold (1.48 log units) above the measured number; measured number outside the range, below it.
By their numbers in this assay, from the lowest: compound 4; then compound 1; then compounds 2 and 3 (each within the scatter of the next).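

In this assay, carboxy in place of 3-hydroxypropyl on a saturated chain carbon, nine bonds along the chain from an oxygen on an aromatic ring, gives a 34-fold lower number from compound 2 to compound 4 (1.53 log units; beyond the scatter). Among the compounds shown here, this is the first single-place step, and it shows that this position responds strongly to the group it carries. Nothing available explains the size of this step.

Still open, as far as these compounds go, is whether the step follows from the carboxy group itself or from the shorter chain that comes with it. An amide or a methyl ester at this position, or a longer chain ending in carboxy, would help to separate the two.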